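Dechlorination of a cyclic sulfonyl urea series: cytotoxicity

A few compounds are considered here, and "the series" means these few. Any claim that something is new, unique, unknown or untested is made for them only; others in the source may bear on it.

Measured so far:
compound 1, `O=C1c2ccccc2N(Cc2ccccc2Cl)S(=O)(=O)N1COCc1ccccc1`, 22200 nM
compound 2, `O=C1c2ccccc2N(Cc2ccccc2)S(=O)(=O)N1COCc1ccccc1`, 100000 nM
compound 3, `O=C1c2ccccc2N(Cc2ccc(Cl)cc2)S(=O)(=O)N1Cc1ccc(Cl)cc1`, 35800 nM

In a functional assay on CCRF-CEM cells (Homo sapiens) for inhibition (a higher number here means that more compound is tolerated, a lower number that less compound is tolerated), compound 1 gives 22200 nM. Compound 2 carries hydrogen in place of chloro on an aromatic carbon, and this change gave a 4.5-fold higher number from compound 1 to compound 2 (0.65 log units; beyond the scatter). Compound 3 gives 35800 nM in this assay; how its core differs from that of compound 1 is not broken down here. The unmeasured compound 4, `O=C1c2ccccc2N(Cc2ccc(Cl)cc2)S(=O)(=O)N1Cc1ccccc1`, carries hydrogen in place of chloro on an aromatic carbon relative to compound 3. This is the same kind of change as from compound 1 to compound 2, but the place differs: there the chloro sat ortho to a large group, here para to a large group. Because compound 1 to compound 2 showed a 4.5-fold higher number from compound 1 to compound 2 (0.65 log units; beyond the scatter), a step of similar direction is expected from compound 3 to compound 4, a 2.2-fold higher number from compound 3 to compound 4 (0.35 log units; beyond the scatter). Compound 4 is therefore expected to give 80000 nM, between 35000 nM and 200000 nM.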

Compound 4, half-maximal cytotoxic concentration: 19700 nM
Compound 4: the middle estimate sits 4.1-fold (0.61 log units) above what was measured; the measured number lies below the stated range.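

In this assay, hydrogen in place of chloro on the 4-chlorobenzyl group gave a 1.8-fold lower number from compound 3 to compound 4 (0.26 log units; within the scatter), so on this core, para to a large group, the change has no effect that stands clear of the scatter. The change therefore did not carry over from the earlier pair with the same size, and the two steps differ: the same change on two cores in this assay, a 4.5-fold higher number (0.65 log units; beyond the scatter) from compound 1 to compound 2 and a 1.8-fold lower number (0.26 log units; within the scatter) from compound 3 to compound 4, 8.2-fold (0.91 log units) apart, beyond the scatter of two such steps. This shows that a step read on one core cannot be assumed on the other, but it does not show what separates them, as the two pairs differ both in the place of the chloro and elsewhere in the structure.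

Left open is how each core would respond with the chloro in the other pair's place. Also open, going by these compounds, is whether a fluoro, a methoxy or an amine at these places would shift the number.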